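Triterpenoid esters and carbamates against breast cancer cell growth

A few compounds are considered here, and "the series" means these few. Any claim that something is new, unique, unknown or untested is made for them only; others in the source may bear on it.

Measured so far:
compound 1, `CC1=CC[C@H]2[C@@H]1CC=C(C)[C@@H](CC[C@H]1[C@]3(C)CC[C@H](OC(=O)c4ccc(C)cc4)C(C)(C)O[C@H]3CC[C@@]1(C)O)C2(C)C`, in a functional assay on MDA-MB-231 cells (Homo sapiens) for antiproliferative activity, read by MTT assay, with a stated time of 72 h (a higher number here means a weaker inhibitor, a lower number a stronger inhibitor), compound 1 gives 32700 nM
compound 2, `CC1=CC[C@H]2[C@H](CC[C@]2(C)O)C(C)(C)[C@@H]1CC[C@H]1[C@]2(C)CC[C@H](OC(=O)NS(=O)(=O)c3ccc(C)cc3)C(C)(C)O[C@H]2CC[C@@]1(C)O`, in this assay compound 2 gives 47100 nM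
compound 3, `CC1=CC[C@H]2[C@H](CC[C@]2(C)O)C(C)(C)[C@@H]1CC[C@H]1[C@]2(C)CC/C(=N/OC(=O)c3ccccc3)C(C)(C)O[C@H]2CC[C@@]1(C)O`, in this assay compound 3 gives 27400 nM

All three numbers sit in the same weak region. Compound 2 has the highest of the three numbers, but its gap to compound 1 and its gap to compound 3 both lie within the usual scatter, so no order among the three compounds can be read from these values.

Compound 4, `CC1=CC[C@H]2[C@H](CC[C@]2(C)O)C(C)(C)[C@@H]1CC[C@H]1[C@]2(C)CC[C@H](OC(=O)c3ccc([N+](=O)[O-])o3)C(C)(C)O[C@H]2CC[C@@]1(C)O`, is not yet measured. It differs from compound 2 in one place: 5-nitrofuran-2-yl in place of ((4-methylphenyl)sulfonyl)amino on a carbonyl carbon. Within the data shown here, nothing measured so far tests this kind of exchange, since no pair of the measured compounds differs in a single place.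

Given that every compound of the shared core measured so far falls in one narrow band, the step from compound 2 to compound 4 in this assay is expected to be small, a 1.6-fold lower number from compound 2 to compound 4 (0.20 log units; within the scatter), if anything toward a lower number, and not clearly beyond the scatter. Compound 4 is therefore estimated at 30000 nM, with a range from 12000 nM to 75000 nM.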

Compound 4, half-maximal inhibitory concentration: 11100 nM
The estimate for compound 4 lay 2.7-fold (0.43 log units) above the measured number, outside the stated range (below it).
By their numbers in this assay, from the lowest: compound 4; then compounds 3, 1 and 2 (each within the scatter of the next).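

In this assay, among these compounds, placing 5-nitrofuran-2-yl instead of ((4-methylphenyl)sulfonyl)amino on the carbonyl carbon gives a 4.2-fold lower number from compound 2 to compound 4 (0.63 log units; beyond the scatter) and so provides the first single-place change, with a step beyond the scatter. The group on this carbonyl carbon can therefore shift the number out of the narrow band seen so far, although the step is only modest. No data bearing on the cause of this step are at hand.

The exchange changes the ring, adds the nitro group and removes the sulfonylamino link all at once, so the compounds shown do not reveal which of these parts accounts for the step. Furan-2-yl without the nitro group and 4-nitrophenyl on the same carbonyl carbon would help to separate these parts.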